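This account rests on a few compounds, and the source may have more. Where it says the series, first, only, none or still open, it means among the compounds named here.

Measured compounds:
- compound 1 `CC(C)N(CCN(C(=O)N(C)C)c1ccccn1)C(C)C`, in a functional assay on the whole organism (stomach) for inhibition, with Canis familiaris (Canis lupus familiaris) as the target, at a dose of 20 mg/kg by the oral route; a higher number here means a stronger effect of the compound at the dose given, a lower number a weaker effect: 17%
- compound 2 `CC(C)N(CCN(C(=O)N(C)C)c1cccc(Cl)n1)C(C)C`, in this assay: 78%

Compound 1 stands at the lowest of the two numbers in this assay; its nearest neighbour is compound 2, which gives 78% in this assay. Among the compounds with values here, the only step between measured compounds is a number 61 percentage points higher from compound 1 to compound 2 (beyond the scatter).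

The unmeasured compound 3 `COc1ccnc(N(CCN(C(C)C)C(C)C)C(=O)N(C)C)c1` differs from compound 1 in one place: methoxy in place of hydrogen on an aromatic carbon. The entering group sits on an aromatic carbon of a six-membered aromatic ring with one nitrogen, meta to a large group and opposite the ring nitrogen.

The step of a number 61 percentage points higher from compound 1 to compound 2 (beyond the scatter) is the only one that bears on this change, and only loosely: it also replaces a hydrogen on an aromatic carbon of the shared core, but with a different group at a different place. That step was large. On that basis a rise is expected for compound 3 in this assay, though a smaller and far less certain one, so that a number 21 percentage points higher from compound 1 to compound 3 (beyond the scatter) is estimated. Compound 3 is thus expected to give 38% in this assay, within a range from 12% to 68%.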

Compound 3, a percentage reported as inhibition, in the whole organism at one dose (the size of the read-out at that dose, not a potency): 84%
Compound 3: the middle estimate sits 46 percentage points below what was measured, and the stated range ends below it.
By their numbers in this assay, from the lowest: compound 1; then compounds 2 and 3 (each within the scatter of the next).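

In this assay, methoxy in place of hydrogen on the aromatic carbon opposite the ring nitrogen, meta to a large group, gives a number 67 percentage points higher from compound 1 to compound 3 (beyond the scatter). This shows that the position opposite the ring nitrogen is one where a single substitution on the shared core goes with a large rise, and that such a rise is not confined to chloro at its different place on the ring, which gives a number 61 percentage points higher from compound 1 to compound 2 (beyond the scatter). Nothing available explains why the methoxy change goes with so large a rise.

The compounds shown leave open whether the rise belongs to methoxy itself or would also follow from another group on the same carbon, such as methyl, fluoro, an amine or a longer ether like ethoxy. They also leave open how methoxy would read at the place chloro holds in compound 2, how chloro would read opposite the ring nitrogen, and how compound 3 would behave at any dose other than the single one tested.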